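A few compounds are considered here, and "the series" means these few. Any claim that something is new, unique, unknown or untested is made for them only; others in the source may bear on it.

Measured compounds:
compound 1, `COc1ccc(CNC(=O)/C=C/c2coc3cc(OC)ccc3c2=O)cc1`, 15700 nM
compound 2, `COc1ccc2c(=O)c(/C=C/C(=O)Nc3ccc(C)cc3)coc2c1`, 39300 nM

Compound 2 gives the highest of the two numbers recorded in a functional assay (QGY7701 cells, Homo sapiens) for inhibition, read by MTT assay, with a stated time of 48 h; on this read-out lower numbers stand for stronger inhibition and higher numbers for weaker inhibition; its nearest neighbour is compound 1, which lies a 2.5-fold higher number from compound 1 to compound 2 (0.40 log units; beyond the scatter) away. Compound 3, `CCOc1ccc(NC(=O)/C=C/c2coc3cc(OC)ccc3c2=O)cc1`, is not yet measured in this assay. It differs from compound 2 by ethoxy in place of methyl on an aromatic carbon.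

Going by the values given here, only one measured step exists, and it bears on this change indirectly: the step from compound 1 to compound 2, a 2.5-fold higher number from compound 1 to compound 2 (0.40 log units; beyond the scatter), swaps the whole group on the amide nitrogen, so it alters more than one feature at once and does not isolate the effect of the substituent on the ring. What the two values show is that the compound carrying an oxygen-bearing group on the ring, compound 1, gave the lower number. Among the compounds with values here, no other pair is available to check this.

On this basis compound 3 is expected to show a small shift, a 1.4-fold lower number from compound 2 to compound 3 (0.15 log units; within the scatter), in the direction of a lower number, with no confidence that it exceeds the scatter. The estimate for compound 3 in this assay is 28000 nM, within a range from 11000 nM to 75000 nM.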

Compound 3, half-maximal inhibitory concentration: > 100000 nM
Compound 3 gave a limit, no number; the forecaster's own chance of this, stated with the estimate: 10%; middle value at least 3.5-fold (0.55 log units) away from the limit.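

Compound 3 gives a limit of the assay and not a number in this assay: the limit of > 100000 nM in this assay, at which 1 of the 3 values shown sits. On the aromatic carbon para to a large group, ethoxy in place of methyl gives an at least 2.5-fold higher number from compound 2 to compound 3 (0.40 log units; beyond the scatter), so the earlier hint from compound 1 that an oxygen-bearing ring substituent goes with a lower number does not hold at this position on the anilide-type ring of the series. With 4-ethoxyphenyl in place of 4-methoxybenzyl on the amide-type nitrogen the result is an at least 6.3-fold higher number from compound 1 to compound 3 (0.80 log units; beyond the scatter), which leaves the 4-methoxybenzyl compound with the lowest number of the three, and this is now a change in the amide group that cannot be read as a ring-substituent effect alone.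

From the compounds shown here alone, the true size of both steps stays open, as a limit sets only one side of them. Also open, going by these compounds, is whether the higher number goes with the oxygen or with the longer group, a question that a plain ethyl or a methoxy at this position would separate, while a hydroxyl or an amine there would show how other groups on this carbon read in this assay.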